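The source may report more compounds than this note shows. Statements on the series, on what has been measured and on what is new or still open speak of the compounds shown alone.

In a functional assay for inhibition of sodium/hydrogen exchanger (Oryctolagus cuniculus) (on this read-out lower numbers stand for stronger inhibition and higher numbers for weaker inhibition), compound 2 `CS(=O)(=O)c1cc(C(=O)N=C(N)N)ccc1-n1ccc(=O)cc1` gives 710 nM, the higher of the two measured numbers. Compound 1 `CCc1cc(Cl)c(S(C)(=O)=O)cc1C(=O)N=C(N)N` gives 63 nM, and the gap between these two lies beyond the usual scatter. Compound 3 `CCc1cc(-n2ccc(=O)cc2)c(S(C)(=O)=O)cc1C(=O)N=C(N)N` is compound 2 with one change: ethyl in place of hydrogen on an aromatic carbon. Within the data shown here, no measured pair isolates this change, but compound 1, which also carries an ethyl group, gives 63 nM, so a move toward stronger inhibition is expected. The step of a 2.8-fold lower number from compound 2 to compound 3 (0.45 log units; beyond the scatter) is expected to be a modest gain. Compound 3 is therefore estimated at 250 nM, within a range from 70 nM to 800 nM.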

Compound 3, half-maximal inhibitory concentration: 930 nM
Beside the measured number, compound 3's estimate is 3.7-fold (0.57 log units) below it; measured number above the stated range.
By their numbers in this assay, from the lowest: compound 1; then compounds 2 and 3 (each within the scatter of the next).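

Ethyl in place of hydrogen on this aromatic carbon, para to a methylsulfonyl group, leaves inhibition unchanged within the scatter, with a 1.3-fold higher number from compound 2 to compound 3 (0.12 log units; within the scatter). With ethyl present in both compounds, the large step appears where a group of 7 heavy atoms, a six-membered aromatic ring with one hetero atom, stands in place of one chlorine atom, with a 15-fold higher number from compound 1 to compound 3 (1.17 log units; beyond the scatter). Nothing at hand says why either step comes out as it does.

Still open, going by these compounds, is how a methyl group or an amine on the ethyl-bearing carbon would compare, and whether a bromine atom in place of the chlorine would match compound 1.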